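The source may report more compounds than this note shows. Statements on the series, on what has been measured and on what is new or still open speak of the compounds shown alone.

Working notes on the series.

Among the compounds with values here, compound 2 `COc1cc2ncnc(N3CCc4ccccc43)c2cc1NC(=O)/C=C/CN(C)C` is the lower of the two numbers measured so far. In a functional assay on PC-3 cells (Homo sapiens) for antiproliferative activity, read by MTT assay, with a stated time of 72 h (a higher number here means a weaker inhibitor, a lower number a stronger inhibitor), compound 2 gives 2190 nM. Compound 1 `C/C=C/C(=O)Nc1cc2c(N3CCCc4ccccc43)ncnc2cc1OC` differs from it in more than one place, so the two cannot be compared as a single step; in this assay compound 1 gives 7520 nM, a higher number than that of compound 2, and the gap between the two lies beyond the usual scatter.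

Compound 3 `COc1cc2ncnc(N3CCCc4ccccc43)c2cc1NC(=O)/C=C/CN(C)C` has not yet been measured. It differs from compound 2 by 1,2,3,4-tetrahydroquinolin-1-yl in place of 2,3-dihydro-1H-indol-1-yl on an aromatic carbon, with the rest of the molecule unchanged. Within the data shown here, no measured pair in the set isolates this change; compound 1 carries the same 1,2,3,4-tetrahydroquinolin-1-yl group but also a different amide side chain, so its value does not read directly on this step.

With nothing in the data to anchor the direction, the step from compound 2 to compound 3 is expected to be small and most likely within the scatter, a 1.4-fold higher number from compound 2 to compound 3 (0.14 log units; within the scatter). For compound 3 in this assay the estimate is 3000 nM, with a range of 1200 nM to 8000 nM.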

Compound 3, half-maximal inhibitory concentration: 1750 nM
Beside the measured number, compound 3's estimate is 1.7-fold (0.23 log units) above it; measured number inside the range.
By their numbers in this assay, from the lowest: compounds 3 and 2 (each within the scatter of the next); then compound 1.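

Working notes, continued.

In this assay, within the data shown here, 1,2,3,4-tetrahydroquinolin-1-yl in place of 2,3-dihydro-1H-indol-1-yl on the aromatic carbon next to the ring nitrogen gives a 1.3-fold lower number from compound 2 to compound 3 (0.10 log units; within the scatter) and so does not separate the two groups, the first reading of this position with all else held constant. The same compound also supplies the first single-place reading of the side chain: dimethylamino in place of hydrogen on the saturated chain carbon gives a 4.3-fold lower number from compound 1 to compound 3 (0.63 log units; beyond the scatter) with the 1,2,3,4-tetrahydroquinolin-1-yl group held fixed, so among these compounds the one step beyond the scatter lies in the side chain and not in the ring exchange. Nothing in hand accounts for either step.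

On these data alone, whether the position tolerates groups further from these two remains open, for example an open-chain N-methylanilino group or a ring with a hetero atom added, such as a benzoxazine. As far as these compounds go, on the side chain, it remains open whether the dimethylamino reading carries over to another amine, such as morpholine or piperidine, or to a longer chain between the amine and the double bond.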